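This account rests on a few compounds, and the source may have more. Where it says the series, first, only, none or still open, it means among the compounds named here.

Measured so far in an ADME assay on MT4 cells (Homo sapiens) for cytotoxicity, read by MTT assay, with a stated time of 5 days; a higher number here means that more compound is tolerated, a lower number that less compound is tolerated:
compound 1 `COc1ccc2nc(NN)sc2c1`: 14.8 ug/mL
compound 2 `NNc1nc2c([N+](=O)[O-])cccc2s1`: 14.5 ug/mL
compound 3 `O=[N+]([O-])c1ccc(-c2nnc(-c3cccnc3)n2Nc2nc3ccc(F)cc3s2)cc1`: >= 108 ug/mL, a limit of the assay rather than a number

Compound 3 stands apart from the other two in that it reaches (the limit of >= 108 ug/mL in this assay, at which 1 of the 3 values shown sits), so no number is known for it. Compound 4 `O=[N+]([O-])c1ccc(-c2nnc(-c3cccnc3)n2Nc2nc3ccc(Cl)cc3s2)cc1` differs from compound 3 by chloro in place of fluoro on an aromatic carbon. Among the compounds with values here, no step between two measured compounds covers this kind of change, so nothing fixes its size or direction. The expected step from compound 3 to compound 4 in this assay is an at least 1.0-fold lower number from compound 3 to compound 4 (0.03 log units; that floor lies within the scatter), none beyond the scatter. For compound 4 the estimate is therefore 100 ug/mL, with a range from 40 ug/mL to 150 ug/mL, and this assay is expected to report only a limit again rather than a number.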

Compound 4, half-maximal cytotoxic concentration: 53.7 ug/mL
Compound 4: middle estimate off by 1.9-fold (0.27 log units), on the high side; the measured number falls inside the stated range.
By their numbers in this assay, from the lowest: compounds 2 and 1 (each within the scatter of the next); then compound 4. At a limit, above all of these: compound 3.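

In this assay, the change from 6-fluoro-1,3-benzothiazol-2-yl to 6-chloro-1,3-benzothiazol-2-yl gives an at least 2.0-fold lower number from compound 3 to compound 4 (0.30 log units; that floor lies within the scatter). Compound 4 gives a number, 53.7 ug/mL, so this position can carry a substituent that brings the read-out within the measurable range of this assay. Compound 3 has only a limit, not a number: the limit of >= 108 ug/mL in this assay, at which 1 of the 4 values shown sits.

Going by these compounds, the true size of the step beyond that floor remains open. Also open, on these data alone, is what an amine or a carboxylic acid on this aromatic carbon would give in this assay.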